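Methyl for fluoro on the hydroxy-bearing ring of compound 1

This account rests on a few compounds, and the source may have more. Where it says the series, first, only, none or still open, it means among the compounds named here.

Compound 1 `N#Cc1ccc(NC(=O)c2ccc(F)cc2O)cc1` is the starting point. In a functional assay on KG-1 cells (Homo sapiens) for cytotoxicity, read by luminescence and CellTiter-Glo, with a stated time of 3 days (on this read-out higher numbers stand for weaker inhibition and lower numbers for stronger inhibition), compound 1 gives 3150 nM. Compound 2 `O=C(Nc1cc(F)cc(F)c1)c1ccc2cccnc2c1O`, built on a different core, gives 3340 nM in this assay; the two values lie within the scatter of each other, so compound 1 stands at the lower of the two numbers without that implying any order between them. Among the measured compounds shown here, no pair of measured compounds differs in a single place, so no measured step sets a scale for what a small change does in this assay.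

Compound 3 `Cc1ccc(C(=O)Nc2ccc(C#N)cc2)c(O)c1` differs from compound 1 in one place: methyl in place of fluoro on an aromatic carbon. The fluoro leaves and a methyl enters on an aromatic carbon of a six-membered aromatic ring of carbon only, meta to a hydroxy group and para to a large group. Nothing measured here shows how such a swap moves the read-out in this assay. The step is expected to be small, a 1.1-fold lower number from compound 1 to compound 3 (0.02 log units; within the scatter), with no direction beyond the scatter. Compound 3 is accordingly estimated at 3000 nM in this assay, within a range from 1200 nM to 8000 nM.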

Compound 3, half-maximal inhibitory concentration: 2560 nM
Estimate against measurement, compound 3: 1.2-fold (0.07 log units) above, within the range that was stated.
By their numbers in this assay, from the lowest: compounds 3, 1 and 2 (each within the scatter of the next).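

In this assay, among the compounds shown here, methyl in place of fluoro on an aromatic carbon, meta to a hydroxy group and para to a large group, gives a 1.2-fold lower number from compound 1 to compound 3 (0.09 log units; within the scatter) and provides the only measured single-place step so far. At this position, the two groups are therefore interchangeable on this read-out: the exchange of one heavy atom for another, with no ring, hydrogen-bond donor, hydrogen-bond acceptor or net charge on either side, produces no change beyond the scatter, so the step gives the series a first reference for a small change on the core of compound 1. No measured information is available to explain why the read-out stays within the scatter for this exchange.

From the compounds shown here alone, whether an amine, a methoxy group, a carboxylic acid or a longer chain such as propyl on this same aromatic carbon would move the read-out beyond the scatter remains open, since fluoro and methyl alone do not show how much change this position can accept. Also open, going by these compounds, is whether the same exchange of fluoro for methyl would give a comparable step at another aromatic carbon of the ring or on a different core.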